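Sulfonamide substitution series: from compound 2 to compound 4

The source may hold more compounds than are shown below. What is called first, only, known or untested is meant among the compounds shown, and "the series" means these compounds.

- compound 1 `CN1CCC(CNS(=O)(=O)c2ccccc2Nc2cc(-c3ccc4ccn(C)c4c3)c3nccnc3c2)C1` at 0.633 h
- compound 2 `Cn1ccc2ccc(-c3cc(Nc4ccccc4S(N)(=O)=O)cc4nccnc34)cc21` at 0.5 h
- compound 3 `CNS(=O)(=O)c1ccccc1Nc1cc(-c2ccc3ccn(C)c3c2)c2nccnc2c1` at 0.2 h
- compound 4 `CN(C)S(=O)(=O)c1ccccc1Nc1cc(-c2ccc3ccn(C)c3c2)c2nccnc2c1` not yet measured

All values come from an ADME assay on microsomes from liver (Mus musculus, strain CD-1) for metabolic stability, read by LC-MS, tested at 2 uM; on this read-out higher numbers stand for a longer-lived compound and lower numbers for a shorter-lived compound. Compound 2 stands in the upper part of this small set at 0.5 h, and the measured step to it is a 1.3-fold lower number from compound 1 to compound 2 (0.10 log units; within the scatter). Compound 3 lies clearly lower. Compound 4 carries dimethylamino in place of amino on a sulfonyl sulfur.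

Within the data shown here, the closest precedent is the change to compound 3, methyl in place of hydrogen on a sulfonamide nitrogen, which gave a 2.5-fold lower number from compound 2 to compound 3 (0.40 log units; beyond the scatter). Substitution alone does not set the direction, however, since compound 1 goes against a simple shortening trend. The step of a 3.2-fold lower number from compound 1 to compound 3 (0.50 log units; beyond the scatter) shows how much the substituent matters. Among the measured compounds shown here, no measured compound has two methyl groups on this nitrogen, so the step is uncertain. The expected step is a 2.8-fold lower number from compound 2 to compound 4 (0.44 log units; beyond the scatter), similar in size and direction to the methyl step. The estimated value for compound 4 is 0.18 h, with an expected range of 0.07 h to 0.45 h.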

Compound 4, half-life: 0.233 h
Compound 4: middle estimate off by 1.3-fold (0.11 log units), on the low side, and the stated range covers the measured number.
By their numbers in this assay, from the lowest: compounds 3 and 4 (each within the scatter of the next); then compounds 2 and 1 (each within the scatter of the next).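

In this assay, dimethylamino in place of amino on the sulfonyl sulfur gives a 2.1-fold lower number from compound 2 to compound 4 (0.33 log units; beyond the scatter), which places compound 4 with compound 3 in the lower pair of the set. A second methyl on the sulfonamide nitrogen brings no readable difference, at a 1.2-fold higher number from compound 3 to compound 4 (0.07 log units; within the scatter), so the drop seen with the first methyl does not extend further. The larger substituent also stays apart from dimethylamino, with a 2.7-fold lower number from compound 1 to compound 4 (0.43 log units; beyond the scatter), leaving only amino and ((1-methylpyrrolidin-3-yl)methyl)amino in the upper pair.

Open, going by these compounds, is how a morpholine ring on the sulfonyl sulfur, or a longer chain ending in a hydroxyl group on the sulfonamide nitrogen, would sit relative to these two pairs. Nothing available accounts for the pattern among these four compounds.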